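The source may hold more compounds than are shown below. What is called first, only, known or untested is meant among the compounds shown, and "the series" means these compounds.

Measured in an ADME assay on SH-SY5Y cells (Homo sapiens) for cytotoxicity, read by MTT assay, with a stated time of 72 h; a higher number here means a weaker inhibitor, a lower number a stronger inhibitor:
- compound 1 `O=C(CN1CCN(C(=O)c2ccc(Cl)cc2)CC1)N1CCN(CCCc2c[nH]c3ccc(F)cc23)CC1` gives 125000 nM
- compound 2 `COc1ccc(C(=O)N2CCN(CC(=O)N3CCN(CCCc4c[nH]c5ccc(F)cc45)CC3)CC2)cc1` gives 161000 nM
- compound 3 `O=C(CN1CCN(C(=O)c2ccc(Br)cc2)CC1)N1CCN(CCCc2c[nH]c3ccc(F)cc23)CC1` gives 47400 nM

Compound 3 holds the lowest of the three numbers, and its two steps, a 2.6-fold lower number from compound 1 to compound 3 (0.42 log units; beyond the scatter) and a 3.4-fold lower number from compound 2 to compound 3 (0.53 log units; beyond the scatter), are both beyond the scatter. The remaining step, a 1.3-fold higher number from compound 1 to compound 2 (0.11 log units; within the scatter), does not separate compound 1 from compound 2.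

Compound 4 `Cc1ccc(C(=O)N2CCN(CC(=O)N3CCN(CCCc4c[nH]c5ccc(F)cc45)CC3)CC2)cc1` is next: methyl in place of bromo on an aromatic carbon. Within the data shown here, no measured step involves methyl, so the guide is indirect. The two modest steps into compound 3 suggest that losing the bromo gives back a rise of similar size in this assay. The expected step is a 2.3-fold higher number from compound 3 to compound 4 (0.37 log units; beyond the scatter). For compound 4 the estimate is 110000 nM, with an expected range from 50000 nM to 230000 nM.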

Compound 4, half-maximal inhibitory concentration: 119000 nM
The estimate for compound 4 lay 1.1-fold (0.03 log units) below the measured number; the range from low to high includes it.
By their numbers in this assay, from the lowest: compound 3; then compounds 4, 1 and 2 (each within the scatter of the next).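

In this assay methyl in place of bromo, para to a large group, gives a 2.5-fold higher number from compound 3 to compound 4 (0.40 log units; beyond the scatter) and compound 3 now stands apart from a third neighbour. Meanwhile a 1.4-fold lower number from compound 2 to compound 4 (0.13 log units; within the scatter) and a 1.1-fold lower number from compound 1 to compound 4 (0.02 log units; within the scatter) both lie within the scatter, so methyl, methoxy and chloro are not separated at this place and only bromo stands out among the four groups. Nothing measured here gives a reason for this.

As far as these compounds go, whether the separation is particular to bromo stays open: iodo, an amine or a carboxylic acid at this place could group with bromo or with the other three. The separation also rests on compound 3 alone.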